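The source may hold more compounds than are shown below. What is called first, only, known or untested is meant among the compounds shown, and "the series" means these compounds.

Working notes on the series. Compound 1 `CCCCNC(=O)N1CC1C#N` is the non-aromatic member; in a functional assay on L1210 cells (Mus musculus) for inhibition, read by MTT assay (a lower number here means a stronger inhibitor, a higher number a weaker inhibitor), compound 1 gives 12000 nM. Compound 2 `N#CC1CN1C(=O)Nc1ccc(F)cc1` carries a fluoro on a six-membered aromatic ring of carbon only, and in this assay compound 2 gives 7300 nM. Compound 3 `N#CC1CN1C(=O)Nc1ccc([N+](=O)[O-])cc1` carries nitro on the same kind of ring, and in this assay compound 3 gives 2600 nM, the lowest of the three numbers; its nearest neighbour is compound 2 and the furthest is compound 1. Among the measured compounds shown here, the single one-change step among the measured compounds is a 2.8-fold lower number from compound 2 to compound 3 (0.45 log units; beyond the scatter).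

Compound 4 `N#CC1CN1C(=O)Nc1ccc(C(F)(F)F)cc1` is the next case: trifluoromethyl in place of nitro on an aromatic carbon. For the measured compounds named here, no measured step exchanges nitro for trifluoromethyl, so the expectation rests on what the three numbers show. Compound 2 and compound 3 bracket the range covered so far by a substituent on the aromatic ring, and the step of a 2.8-fold lower number from compound 2 to compound 3 (0.45 log units; beyond the scatter) was modest. A number close to compound 3 is therefore expected, possibly drifting toward compound 2; the expected step of a 1.3-fold higher number from compound 3 to compound 4 (0.13 log units; within the scatter) is within or only just beyond the scatter. For compound 4 the estimate in this assay is 3500 nM, within a range from 1500 nM to 8000 nM.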

Compound 4, half-maximal inhibitory concentration: 7800 nM
The estimate for compound 4 lay 2.2-fold (0.35 log units) below the measured number, within the range that was stated.
By their numbers in this assay, from the lowest: compound 3; then compounds 2, 4 and 1 (each within the scatter of the next).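

In this assay, the substituent on this aromatic carbon, para to a group of 8 heavy atoms, can now be read through more than one exchange: trifluoromethyl in place of nitro gives a 3.0-fold higher number from compound 3 to compound 4 (0.48 log units; beyond the scatter), whereas trifluoromethyl in place of fluoro gives a 1.1-fold higher number from compound 2 to compound 4 (0.03 log units; within the scatter). Among the three compounds with a substituent at this place, compound 3 therefore stands alone with the lowest number, while compound 2 and compound 4 lie within the scatter of each other and cannot be told apart, so the earlier single step from fluoro to nitro now reads as a separation of nitro from both other groups. No available data bear on why nitro and trifluoromethyl differ at this place.

Going by these compounds, how an amine, a carboxylic acid or a methoxy group on this aromatic carbon would stand against compound 3 remains open. Also open, on these data alone, is whether the exchange of nitro for trifluoromethyl would give a step of similar size at another carbon of the ring, or with a chain such as the butyl group of compound 1 changed elsewhere on the shared core.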